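Swapping the vinyl for an acetyl beside the sulfonamide

The source may hold more compounds than are shown below. What is called first, only, known or untested is meant among the compounds shown, and "the series" means these compounds.

In a functional assay for antagonist activity at transient receptor potential cation channel subfamily V member 1 (Rattus norvegicus) (on this read-out lower numbers stand for stronger inhibition and higher numbers for weaker inhibition), three compounds sharing one thioamide core have been measured. Compound 1 `CC(C)(C)c1ccc(CCC(=S)NCc2ccc(NS(C)(=O)=O)c(F)c2)cc1` gives 40 nM, compound 2 `CC(C)(C)c1ccc(CCC(=S)NCc2ccc(NS(C)(=O)=O)c(Cl)c2)cc1` gives 96 nM, and compound 3 `C=Cc1cc(CNC(=S)CCc2ccc(C(C)(C)C)cc2)ccc1NS(C)(=O)=O` gives 61 nM. Compound 3 thus holds the second highest of the three numbers; its nearest neighbour is compound 1, with a 1.5-fold higher number from compound 1 to compound 3 (0.18 log units; within the scatter), and its furthest is compound 2, with a 1.6-fold lower number from compound 2 to compound 3 (0.20 log units; within the scatter), so both of those gaps fall within the scatter. Among the compounds with values here, the only step beyond the scatter is a 2.4-fold higher number from compound 1 to compound 2 (0.38 log units; beyond the scatter).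

Compound 4 `CC(=O)c1cc(CNC(=S)CCc2ccc(C(C)(C)C)cc2)ccc1NS(C)(=O)=O` differs from compound 3 in a single place: acetyl in place of vinyl on an aromatic carbon. Within the data shown here, the two steps that touch the same position, from compound 1 and from compound 2 to compound 3, both lie within the scatter, and the one step beyond it, from compound 1 to compound 2, is modest. Among the measured compounds shown here, none of the measured steps, however, introduces an acetyl or any group with a hydrogen-bond acceptor at this position, so the measured steps give no direct precedent. In the absence of such a precedent, compound 4 is expected to show a 1.3-fold higher number from compound 3 to compound 4 (0.12 log units; within the scatter) in this assay, a step that may well stay within the scatter. The estimate for compound 4 is therefore 80 nM, with a range from 20 nM to 320 nM.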

Compound 4, half-maximal inhibitory concentration: 1000 nM
Estimate against measurement, compound 4: 13-fold (1.10 log units) below, outside the stated range (above it).
By their numbers in this assay, from the lowest: compounds 1, 3 and 2 (each within the scatter of the next, the first and the last beyond it); then compound 4.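

In this assay, the fluoro, chloro and vinyl compounds are separated by no more than a modest step, but acetyl at this position gives a 16-fold higher number from compound 3 to compound 4 (1.21 log units; beyond the scatter), together with a 10-fold higher number from compound 2 to compound 4 (1.02 log units; beyond the scatter) and a 25-fold higher number from compound 1 to compound 4 (1.40 log units; beyond the scatter). Within the data shown here, this is the first large step seen at this position, on an aromatic carbon ortho to a methanesulfonamido group, so the read-out here is far from indifferent to which group is present. Compared with vinyl, acetyl brings one more heavy atom, an oxygen, and one hydrogen-bond acceptor, but the data offer no measurement that accounts for the size of this step.

With only acetyl in hand, the oxygen cannot be told apart from the larger group as a whole: an isopropenyl group would hold the same count of heavy atoms with carbon in place of that oxygen, while a methoxy or hydroxymethyl group would keep an oxygen in a different arrangement. On these data alone, it also remains open whether acetyl would give a step of similar size with an ordinary amide in place of the thioamide in the shared core.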